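This account rests on a few compounds, and the source may have more. Where it says the series, first, only, none or still open, it means among the compounds named here.

Of the compounds shown here, three with a shared core have been measured, and a fourth awaits its number. Compound 1 `O=S(=O)(c1cccc2ncccc12)N1CCC(CCN2CCN(c3ccccc3)CC2)CC1` is the plainest of them, and in an assay on HEK293 cells for displacement of a labelled ligand from 5-hydroxytryptamine receptor 7 (Homo sapiens), read by scintillation counting, with a stated time of 1 h (on this read-out higher numbers stand for weaker inhibition and lower numbers for stronger inhibition), compound 1 gives 209 nM. Compound 2 `O=S(=O)(c1cccc2ncccc12)N1CCC(CCN2CCN(c3ccc(Cl)cc3)CC2)CC1` differs from compound 1 in one place only, a chloro group in place of a hydrogen, and in this assay compound 2 gives 37 nM. That single exchange produced a 5.6-fold lower number from compound 1 to compound 2 (0.75 log units; beyond the scatter), a modest gain in binding but a clear one.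

Compound 3 `O=S(=O)(c1cncc2ccccc12)N1CCC(CCN2CCN(c3cccc(Cl)c3)CC2)CC1` differs from compound 2 in two places at once, so no single step can be read between them; in this assay compound 3 gives 18 nM, the lowest of the three numbers, clearly apart from compound 2 and further still from compound 1.

Compound 4 `O=S(=O)(c1cncc2ccccc12)N1CCC(CCN2CCN(c3ccc(Cl)c(Cl)c3)CC2)CC1` differs from compound 3 by chloro in place of hydrogen on an aromatic carbon. For the measured compounds named here, the only step of the same kind is the one from compound 1 to compound 2, where a first chloro group lowered the number modestly. A second chloro group on a ring that already carries one is expected to help less, if at all. For compound 4 the expected value in this assay is 12 nM, with a range from 5 nM to 30 nM, an expected 1.5-fold lower number from compound 3 to compound 4 (0.18 log units; within the scatter).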

Compound 4, inhibition constant: 36 nM
The estimate for compound 4 lay 3.0-fold (0.48 log units) below the measured number; measured number above the stated range.
By their numbers in this assay, from the lowest: compounds 3, 4 and 2 (each within the scatter of the next, the first and the last beyond it); then compound 1.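

Going from the 3-chlorophenyl of compound 3 to the 3,4-dichlorophenyl of compound 4 places the new chloro group ortho to a chloro group and para to a large group, and it gives a 2.0-fold higher number from compound 3 to compound 4 (0.30 log units; within the scatter), so these two compounds cannot be told apart by their binding numbers. The earlier compounds shown here showed only a clear gain from adding a chloro group, and this result shows that such a gain does not carry over to every compound: the same change on two cores in this assay, a 5.6-fold lower number (0.75 log units; beyond the scatter) from compound 1 to compound 2 and a 2.0-fold higher number (0.30 log units; within the scatter) from compound 3 to compound 4, 11-fold (1.05 log units) apart, beyond the scatter of two such steps The two steps differ in more than one respect, since the ring in compound 3 already carries a chloro group and the rest of its core also differs from that of compound 1, and these compounds cannot show which of those differences matters.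

Still open, going by these compounds, is how the core of compound 3 would respond to a chloro group at this place with no other chloro group on the ring. Also open, on these data alone, is whether a fluoro, methyl or methoxy group at the same place would behave like chloro.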